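From 1-cyclopropylethyl to 1-cyclopropyl-2-methoxyethyl on the shared core

The source may report more compounds than this note shows. Statements on the series, on what has been measured and on what is new or still open speak of the compounds shown alone.

Measured in an ADME assay on microsomes from liver (Rattus norvegicus) for metabolic stability, with a stated time of 10 min; a lower number here means that less of the compound is left, a higher number that more of the compound is left:
Compound 1 `Cc1nc2c(cc1Nc1nc(Cl)cn([C@H](C)C3CC3)c1=O)COC2`: "not determined" (no result reported)
Compound 2 `COc1nc(C)c(Nc2nc(Cl)cn([C@H](C)C3CC3)c2=O)c(OC)n1`: 86%

Going by the values given here, compound 2 holds the only number in this set, since compound 1 has no reported result, so it cannot be ranked against anything. Compound 3 `COC[C@@H](C1CC1)n1cc(Cl)nc(Nc2c(C)nc(OC)nc2OC)c1=O` keeps the core of compound 2 and changes one group on an aromatic nitrogen: 1-cyclopropyl-2-methoxyethyl in place of 1-cyclopropylethyl on an aromatic nitrogen. Among the compounds with values here, with no measured step as a guide, a modest fall in this assay is expected, an estimated a number 12 percentage points lower from compound 2 to compound 3 (beyond the scatter). That expectation is anchored only by compound 2 at 86%. For compound 3 the estimated value is 74%, with an expected range from 52% to 90%.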

Compound 3, percent of the compound remaining: 71%
Compound 3: middle estimate off by 3 percentage points, on the high side; the measured number falls inside the stated range.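

Going by these compounds alone, this gives the first measured step at this position: in this assay, 1-cyclopropyl-2-methoxyethyl in place of 1-cyclopropylethyl on the aromatic nitrogen gives a number 15 percentage points lower from compound 2 to compound 3 (beyond the scatter) and so the position responds to this change. Even with the added hydrogen-bond acceptor, compound 3 keeps 71% in this read-out. Nothing at hand accounts for the step. On these data alone, whether a hydroxyl group or a longer ether chain here would move the number further remains open. So does whether the same step would appear on another core.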